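From pyrrolidin-1-yl to 1,3-thiazolidin-3-yl on the carbonyl

The source may hold more compounds than are shown below. What is called first, only, known or untested is meant among the compounds shown, and "the series" means these compounds.

Compound 1, `Cc1nc(N2CCN(C(=O)[C@@H]3CN[C@H](C(=O)N4CCCC4)C3)CC2)no1`: 960 nM in an assay on a cell-free system (plasma) for inhibition of Dipeptidyl peptidase 4 (Rattus norvegicus), read by fluorescence; a lower number here means a stronger inhibitor, a higher number a weaker inhibitor
Compound 2, `O=C([C@@H]1CN[C@H](C(=O)N2CCCC2)C1)N1CCN(c2nc(-c3ccccc3)ns2)CC1`: 150 nM
Compound 3, `Cc1nsc(N2CCN(C(=O)[C@H]3C[C@@H](C(=O)N4CCCC4)N[C@H]3C)CC2)n1`: 69 nM

Compound 3 has the lowest number of the three in this assay; compound 2 sits above it by a gap beyond the usual scatter, and compound 1 lies further away still. Compound 4, `Cc1nsc(N2CCN(C(=O)[C@H]3C[C@@H](C(=O)N4CCSC4)N[C@H]3C)CC2)n1`, differs from compound 3 by 1,3-thiazolidin-3-yl in place of pyrrolidin-1-yl on a carbonyl carbon. For the measured compounds named here, no measured pair shows this same change, so its size can only be estimated. The two rings match in size and in the count of heavy atoms, with one sulfur entering, so the step is expected to stay within the scatter, leaning if anything toward a slightly higher number, as a 1.3-fold higher number from compound 3 to compound 4 (0.12 log units; within the scatter). Compound 4 is therefore expected at about 90 nM, in the range 35 nM to 250 nM.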

Compound 4, half-maximal inhibitory concentration: 60 nM
For compound 4 the middle estimate is 1.5-fold (0.18 log units) above the measured one; the range from low to high includes it.
By their numbers in this assay, from the lowest: compounds 4 and 3 (each within the scatter of the next); then compound 2; then compound 1.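

In this assay, for the compounds shown here, this is the first direct comparison at this carbonyl: replacing pyrrolidin-1-yl with 1,3-thiazolidin-3-yl gives a 1.2-fold lower number from compound 3 to compound 4 (0.06 log units; within the scatter), so the two rings cannot be told apart here. In this pair, a sulfur atom in the five-membered ring leaves the number unchanged within the scatter. No available evidence explains this result.

As far as these compounds go, it remains open how a six-membered piperidin-1-yl ring or an open-chain diethylamino group would behave on this carbonyl. From the compounds shown here alone, whether the same swap would give a similar result on the core of compound 1 or compound 2 is also open.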